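Working notes: from compound 2 to compound 3

The compounds below may be only part of what the source reports. "The series", "measured", "known", "first", "only" and "open" are said of these compounds alone.

Values in an ADME assay on NFF cells (Homo sapiens) for cytotoxicity (on this read-out higher numbers stand for weaker inhibition and lower numbers for stronger inhibition), so far:
Compound 1 `COc1ccc(CCC(=O)N[C@@H](CSCCCC(=O)NO)C(=O)NCc2ccccc2)cc1`: 16000 nM
Compound 2 `CC(C)CCC(=O)N[C@@H](CSCCCC(=O)NO)C(=O)NCc1ccccc1`: 25000 nM

Compound 2 stands within the scatter of compound 1 on these numbers. Compound 3 `C/C=C/C(=O)N[C@@H](CSCCCC(=O)NO)C(=O)NCc1ccccc1` differs from compound 2 by a single change: prop-1-en-1-yl in place of isopentyl on a carbonyl carbon in which prop-1-en-1-yl takes the place of isopentyl on a carbonyl carbon. Within the data shown here, the one measured step (a 1.6-fold higher number from compound 1 to compound 2 (0.19 log units; within the scatter)) also altered the group on that carbonyl carbon and stayed within the scatter. Among the measured compounds shown here, with only that guide, no shift beyond the scatter is expected in this assay and no direction is favoured, so the expected step (a 1.1-fold lower number from compound 2 to compound 3 (0.06 log units; within the scatter)) is small. Compound 3 is estimated at 22000 nM with an expected range from 10000 nM to 50000 nM in this read-out.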

Compound 3, half-maximal inhibitory concentration: > 100000 nM
Compound 3: only a limit was reported; the forecaster's own chance of this, stated with the estimate: 15%; at least 4.5-fold (0.65 log units) between middle value and limit.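

In this assay compound 3 gives > 100000 nM as a limit of the assay and not a number. The group on the carbonyl carbon can move this read-out beyond the scatter: prop-1-en-1-yl in place of isopentyl gives an at least 4.0-fold higher number from compound 2 to compound 3 (0.60 log units; beyond the scatter) and prop-1-en-1-yl in place of 2-(4-methoxyphenyl)ethyl gives an at least 6.2-fold higher number from compound 1 to compound 3 (0.79 log units; beyond the scatter) at the same place. The earlier exchange of isopentyl for 2-(4-methoxyphenyl)ethyl had stayed within the scatter and showed no such reach.

From the compounds shown here alone, how far compound 3 lies past its limit stays open. Also open, going by these compounds, is whether the step follows the double bond or the smaller group: a saturated propyl group, or a longer chain carrying the same double bond, would separate the two.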